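From a Nitrophenyl Arm to a Chlorohydroxyphenyl Arm

The source may hold more compounds than are shown below. What is called first, only, known or untested is meant among the compounds shown, and "the series" means these compounds.

Three compounds have been measured in a functional assay on SK-OV-3 cells (Homo sapiens) for antiproliferative activity, read by MTT assay, with a stated time of 24 h; on this read-out lower numbers stand for stronger inhibition and higher numbers for weaker inhibition:
Compound 1, `CCN(CC)c1ccc(/C=C/C(=O)c2ccc(OC)c3c2OC(C)(C)C=C3)cc1`, gives 610 nM.
Compound 2, `COc1ccc(C(=O)/C=C/c2ccc([N+](=O)[O-])cc2)c2c1C=CC(C)(C)O2`, gives 3420 nM.
Compound 3, `COc1ccc(C(=O)/C=C/c2ccc(C(F)(F)F)cc2)c2c1C=CC(C)(C)O2`, gives only a limit of the assay, > 10000 nM.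

Among the two actual numbers, compound 2 holds the higher one; the nearest value is that of compound 1, and the step between them is a 5.6-fold higher number from compound 1 to compound 2 (0.75 log units; beyond the scatter). The remaining value is a limit (the limit of > 10000 nM in this assay, at which 1 of the 3 values shown sits).

Compound 4, `COc1ccc(C(=O)/C=C/c2cc(Cl)ccc2O)c2c1C=CC(C)(C)O2`, has not yet been measured. It differs from compound 2 by 5-chloro-2-hydroxyphenyl in place of 4-nitrophenyl on a double-bonded chain carbon bound to a double-bonded chain carbon. All measured steps change the group on this same aromatic ring: a 5.6-fold higher number from compound 1 to compound 2 (0.75 log units; beyond the scatter), an at least 16-fold higher number from compound 1 to compound 3 (1.21 log units; beyond the scatter) and an at least 2.9-fold higher number from compound 2 to compound 3 (0.46 log units; beyond the scatter). Within the data shown here, none of them exchanges a nitro for a 5-chloro-2-hydroxyphenyl, so they show only that this ring tolerates changes unevenly, with moves from modest to large. For compound 4 a modest move in either direction is therefore plausible, and the estimate in this assay is 2000 nM, expected to lie between 500 nM and 8000 nM. For compound 4 this corresponds to an expected step of a 1.7-fold lower number from compound 2 to compound 4 (0.23 log units; within the scatter).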

Compound 4, half-maximal inhibitory concentration: 6270 nM
For compound 4 the middle estimate is 3.1-fold (0.50 log units) below the measured one, and the stated range covers the measured number.
By their numbers in this assay, from the lowest: compound 1; then compounds 2 and 4 (each within the scatter of the next). At a limit, above all of these: compound 3.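

In this assay, putting 5-chloro-2-hydroxyphenyl in place of 4-nitrophenyl on this double-bonded chain carbon gives a 1.8-fold higher number from compound 2 to compound 4 (0.26 log units; within the scatter), so the data do not separate compound 2 from compound 4. The earlier steps shown here exchanged one group on the aromatic ring, whereas this one replaces the whole arm: the nitro leaves, a chlorine and a hydroxy group enter, and a hydrogen-bond donor appears that the arm of compound 2 lacks, yet the two numbers stay within the usual scatter of each other. This position can therefore hold two quite differently decorated phenyl arms at a similar level, but nothing measured here accounts for that similarity.

From the compounds shown here alone, the chlorine and the hydroxy group enter together, so what each contributes remains open, and arms carrying only a chlorine or only a hydroxy group would be needed to tell them apart. Going by these compounds, it is also open whether a plain amino group or a carboxylic acid on this ring would come closer to the diethylamino arm of compound 1 or to the nitro arm of compound 2.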